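The source may report more compounds than this note shows. Statements on the series, on what has been measured and on what is new or still open speak of the compounds shown alone.

Notes on the series. Compound 1 `C[C@H](/N=C(\S)Nc1ccccn1)c1cccc2ccccc12` in a functional assay on RBL-2H3 cells (Rattus norvegicus) for inhibition (on this read-out higher numbers stand for weaker inhibition and lower numbers for stronger inhibition), gives > 100000 nM, which is a limit of the assay rather than a number. Compound 2 `C[C@H](/N=C(\S)Nc1nc2ccccc2s1)c1cccc2ccccc12` in this assay gives > 100000 nM, likewise a limit. Among the compounds with values here, both values sit at the limit of > 100000 nM in this assay, at which 2 of the 2 values shown sit, so compound 1 cannot be placed relative to compound 2, and no measured step is available to size. Compound 3 `Cc1csc(N/C(S)=N/[C@@H](C)c2cccc3ccccc23)n1` carries 4-methyl-1,3-thiazol-2-yl in place of pyridin-2-yl on an amine nitrogen. With both measured values at the limit, no shift beyond the scatter is anticipated, and the expected step in this assay is a number no higher from compound 1 to compound 3 (the limit leaves the size open). Compound 3 is therefore expected near 100000 nM, with a range of 30000 nM to 300000 nM, most likely reported again as a limit.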

Compound 3, half-maximal inhibitory concentration: 83200 nM
Beside the measured number, compound 3's estimate is 1.2-fold (0.08 log units) above it; measured number inside the range.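

In this assay, within the data shown here, the 4-methyl-1,3-thiazol-2-yl group on this amine nitrogen gives the only value shown that is a number rather than a limit: compound 3 gives 83200 nM. The change reads as an at least 1.2-fold lower number from compound 1 to compound 3 (0.07 log units; that floor lies within the scatter), so only a floor is known, and it does not establish a real gain. The true size of the step stays unknown because the reference value is a limit: the limit of > 100000 nM in this assay, at which 2 of the 3 values shown sit.

Open, on these data alone, is whether the methyl group contributes to this value. Also open, as far as these compounds go, is whether a carboxylic acid, an amine or a longer chain on the same ring would give a step beyond the scatter.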